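From Chain to Aromatic Ring in Compound 2

The source may hold more compounds than are shown below. What is called first, only, known or untested is meant among the compounds shown, and "the series" means these compounds.

Going by the values given here, in a functional assay on A549 cells (Homo sapiens) for inhibition, read by MTT assay, with a stated time of 72 h (a higher number here means a weaker inhibitor, a lower number a stronger inhibitor), compound 2 (`O=C(CCCCCN(Cc1ccc(F)cc1)c1ncc(C(=O)NCCCn2ccnc2)s1)NO`) gives 54000 nM as the higher of the two numbers so far, which makes it the weaker inhibitor of the pair. Compound 1 (`O=C(/C=C/c1ccc(CN(Cc2ccc(F)cc2)c2ncc(C(=O)NCCCn3ccnc3)s2)cc1)NO`) gives 2700 nM in the same test. Compound 3 (`O=C(NO)c1ccc(CN(Cc2ccc(F)cc2)c2ncc(C(=O)NCCCn3ccnc3)s2)cc1`) has not yet been measured. The change from compound 2 (4-(hydroxycarbamoyl)phenyl in place of 4-(hydroxycarbamoyl)butyl on a saturated chain carbon bound to a nitrogen on an aromatic ring) puts 4-(hydroxycarbamoyl)phenyl in place of 4-(hydroxycarbamoyl)butyl on a saturated chain carbon bound to a nitrogen on an aromatic ring. Among the compounds with values here, only one measured step bears on this (a 20-fold higher number from compound 1 to compound 2 (1.30 log units; beyond the scatter)) and it was large. In that step, 4-(hydroxycarbamoyl)butyl replaced 4-(2-(hydroxycarbamoyl)ethenyl)phenyl, so the ring-bearing group gave the lower number. Compound 3 also carries a six-membered aromatic ring, but it has no ethenyl link, so only part of that gap may be recovered. A single step is thin evidence, and the forecast is uncertain. The expected change is a large fall, with an estimated 6.8-fold lower number from compound 2 to compound 3 (0.83 log units; beyond the scatter) in this assay as the best guess. For compound 3 the estimated value is 8000 nM with an expected range of 2000 nM to 32000 nM around it.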

Compound 3, half-maximal inhibitory concentration: 7300 nM
Compound 3: middle estimate off by 1.1-fold (0.04 log units), on the high side; the range from low to high includes it.
By their numbers in this assay, from the lowest: compound 1; then compound 3; then compound 2.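

Replacing the open chain with the aromatic ring lowers the number on its own in this assay, giving a 7.4-fold lower number from compound 2 to compound 3 (0.87 log units; beyond the scatter), so the six-membered aromatic ring matters at this position even without an ethenyl link, and compound 1 and compound 2 alone could not show this. Removing the ethenyl link from the ring-bearing group has a smaller effect, but one still beyond the usual scatter, giving a 2.7-fold higher number from compound 1 to compound 3 (0.43 log units; beyond the scatter), so the ring and the ethenyl link each contribute to the gap that first appeared between compound 1 and compound 2. The measurements show only these differences in the numbers and offer nothing that explains them.

On these data alone, it remains open whether the double bond itself matters or only the added length, which 2-(hydroxycarbamoyl)ethyl in place of 2-(hydroxycarbamoyl)ethenyl on an aromatic carbon would help to separate. Also open, as far as these compounds go, is whether the hydroxycarbamoyl group is needed in this cell assay, a question that a carboxylic acid in its place would address.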